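Sulfamate Amides: From Compound 2 to Compound 3

The source may hold more compounds than are shown below. What is called first, only, known or untested is meant among the compounds shown, and "the series" means these compounds.

Measured compounds:
Compound 1, `CN(C)CCN(CCN(C)C)c1cccc(C(=O)N2CCc3ccc(OS(N)(=O)=O)cc3C2)c1`: 17.1%
Compound 2, `CN(CCCN1CCCCC1)c1ccc(C(=O)N2CCc3ccc(OS(N)(=O)=O)cc3C2)cc1`: 40.7%

In an assay on HEK293 cells for inhibition of Steryl-sulfatase (Homo sapiens), tested at 1 uM (a lower number here means a weaker effect, a higher number a stronger effect of the compound at the concentration tested), compound 2 stands highest of the two numbers, with compound 1 the nearest at a number lower by more than the usual scatter. Compound 3, `CCN(Cc1cccc(Br)c1)c1ccc(C(=O)N2CCc3ccc(OS(N)(=O)=O)cc3C2)cc1`, has not yet been measured. It differs from compound 2 by (3-bromobenzyl)(ethyl)amino in place of methyl(3-(piperidin-1-yl)propyl)amino on an aromatic carbon. Going by the values given here, no step of this kind has been measured here, so its size is unknown. The change is expected to give a step of a number 0.7 percentage points lower from compound 2 to compound 3 (within the scatter) that may fall within the scatter, in either direction. Compound 3 is therefore estimated at 40%, between 15% and 65%.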

Compound 3, a percentage reported as inhibition, at one concentration (the size of the read-out at that concentration, not a potency): 97.2%
Compound 3: the middle estimate sits 57.2 percentage points below what was measured; the measured number lies above the stated range.
By their numbers in this assay, from the lowest: compound 1; then compound 2; then compound 3.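

In this assay, the group on this aromatic carbon, para to a large group, matters greatly: (3-bromobenzyl)(ethyl)amino in place of methyl(3-(piperidin-1-yl)propyl)amino gives a number 56.5 percentage points higher from compound 2 to compound 3 (beyond the scatter), even though both groups have the same count of heavy atoms. The change swaps a six-membered non-aromatic ring for a six-membered aromatic ring of carbon only and adds bromine. Nothing available explains why the step is so large.

Which part of the entering group carries the gain remains open. A chlorine in place of the bromine, or a methyl in place of the ethyl, would help separate these parts.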